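A few compounds are considered here, and "the series" means these few. Any claim that something is new, unique, unknown or untested is made for them only; others in the source may bear on it.

Working notes on the series. In a functional assay on PC-3 cells (Homo sapiens) for antiproliferative activity, read by MTT assay, with a stated time of 48 h (on this read-out lower numbers stand for stronger inhibition of growth and higher numbers for weaker inhibition of growth), compound 1 (`Cc1ccc(-c2cnc(N(Cc3ccccc3)Cc3ccc(C(=O)NO)cc3)s2)cc1`) gives 10400 nM, compound 2 (`Cc1ccc(-c2cnc(N(Cc3ccc(C(=O)NO)cc3)CC(C)C)s2)cc1`) gives 9340 nM and compound 3 (`Cc1ccc(OCCCN(Cc2ccc(C(=O)NO)cc2)c2ncc(-c3ccc(C)cc3)s2)cc1`) gives 9330 nM. Compound 3 therefore stands within the scatter of both other compounds, and the numbers set no order among the three.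

The next structure is compound 4 (`CCCCN(Cc1ccc(C(=O)NO)cc1)c1ncc(-c2ccc(C)cc2)s1`). Its difference from compound 3 is methyl in place of 4-methylphenoxy on a saturated chain carbon, three bonds along the chain from a nitrogen on an aromatic ring. In words, this is methyl in place of 4-methylphenoxy on a saturated chain carbon, three bonds along the chain from a nitrogen on an aromatic ring, so that 3-(4-methylphenoxy)propyl gives way to butyl.

Among the compounds with values here, three measured steps bear on this change, as each alters the same chain: a 1.1-fold lower number from compound 1 to compound 2 (0.05 log units; within the scatter), a 1.1-fold lower number from compound 1 to compound 3 (0.05 log units; within the scatter) and a 1.0-fold lower number from compound 2 to compound 3 (0.00 log units; within the scatter). All three lie within the scatter, including the two that add or remove 4-methylphenoxy. No step beyond the scatter is therefore expected in this assay, and the estimated step is a 1.0-fold higher number from compound 3 to compound 4 (0.01 log units; within the scatter). For compound 4 the estimate is 9500 nM, with an expected range from 5000 nM to 18000 nM.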

Compound 4, concentration for 50% growth inhibition: 6410 nM
Beside the measured number, compound 4's estimate is 1.5-fold (0.17 log units) above it; the range from low to high includes it.
By their numbers in this assay, from the lowest: compounds 4, 3, 2 and 1 (each within the scatter of the next).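

In this assay, 3-(4-methylphenoxy)propyl gives way to butyl with a 1.5-fold lower number from compound 3 to compound 4 (0.16 log units; within the scatter), so the 4-methylphenoxy group, with its aromatic ring and hydrogen-bond acceptor, can leave this chain without a step beyond the scatter. The unbranched chain of compound 4 also stays within the scatter of the isopropyl and phenyl ends, with a 1.5-fold lower number from compound 2 to compound 4 (0.16 log units; within the scatter) and a 1.6-fold lower number from compound 1 to compound 4 (0.21 log units; within the scatter), and all four compounds thus remain unseparated at this position. No measurement shown bears on the cause of these small steps.

From the compounds shown here alone, what an amine or a carboxylic acid at the end of this chain would do in this assay remains open. So does whether a chain longer than 3-(4-methylphenoxy)propyl, or a chain as short as methyl, would give a step beyond the scatter.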